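Replacing the pyrazole on the enone ring of compound 2

The compounds below may be only part of what the source reports. "The series", "measured", "known", "first", "only" and "open" are said of these compounds alone.

Measured so far: compound 1 `C[C@@H](O[C@H]1CN2C(=O)C=C(c3ccc(C#N)cc3)CC2[C@@H]1c1ccc(F)cc1)c1cc(C(F)(F)F)cc(C(F)(F)F)c1` with 1.8 nM in an assay on CHO cells for displacement of a labelled ligand from Substance-P receptor (Homo sapiens) (on this read-out lower numbers stand for stronger inhibition and higher numbers for weaker inhibition), and compound 2 `C[C@@H](O[C@H]1CN2C(=O)C=C(c3cnn(C)c3)CC2[C@@H]1c1ccc(F)cc1)c1cc(C(F)(F)F)cc(C(F)(F)F)c1` with 0.13 nM in this assay.

Compound 2 stands lowest of the two numbers; its nearest neighbour, compound 1, lies beyond the scatter, since a 14-fold lower number from compound 1 to compound 2 (1.14 log units; beyond the scatter). Compound 3 `C[C@@H](O[C@H]1CN2C(=O)C=C(C3=CCOCC3)CC2[C@@H]1c1ccc(F)cc1)c1cc(C(F)(F)F)cc(C(F)(F)F)c1` carries a group of 6 heavy atoms (5 carbon, 1 oxygen; one six-membered non-aromatic ring with 1 hetero atom) in place of a group of 6 heavy atoms (4 carbon, 2 nitrogen; one five-membered aromatic ring with 2 hetero atoms), on a double-bonded ring carbon. That single measured step concerns a different exchange, so it bears on this change only loosely. A moderate rise in this assay is therefore expected for compound 3, a 3.8-fold higher number from compound 2 to compound 3 (0.59 log units; beyond the scatter), giving an estimate of 0.5 nM within 0.1 nM to 3 nM.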

Compound 3, half-maximal inhibitory concentration: 0.18 nM
Compound 3: the middle estimate sits 2.8-fold (0.44 log units) above what was measured; measured number inside the range.
By their numbers in this assay, from the lowest: compounds 2 and 3 (each within the scatter of the next); then compound 1.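

In this assay the double-bonded ring carbon takes a six-membered non-aromatic ring with 1 hetero atom as well as it takes 1-methyl-1H-pyrazol-4-yl, with a 1.4-fold higher number from compound 2 to compound 3 (0.14 log units; within the scatter) and so, among these compounds, no aromatic ring is needed at this place. The advantage over the 4-cyanophenyl group does not rest on the pyrazole alone, since a 10-fold lower number from compound 1 to compound 3 (1.00 log units; beyond the scatter) is seen with this ring too.

From the compounds shown here alone, whether an amine or a carboxylic acid on this carbon would hold these numbers in this assay stays open. Nothing available explains the values seen here.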